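This account rests on a few compounds, and the source may have more. Where it says the series, first, only, none or still open, it means among the compounds named here.

Going by the values given here, in a functional assay on HT-29 cells (Homo sapiens) for inhibition, with a stated time of 72 h (on this read-out lower numbers stand for stronger inhibition and higher numbers for weaker inhibition), three compounds sharing one core have numbers so far. Compound 1 (`COc1ccc(S(=O)(=O)N2CCc3cccc(-c4ccc(N)cc4)c32)cc1`) gives 301 nM, compound 2 (`COc1ccc(S(=O)(=O)N2CCc3cccc(-c4ccc(F)cc4)c32)cc1`) gives 85.5 nM, and compound 3 (`COc1ccc(S(=O)(=O)N2CCc3cccc(-c4cccnc4)c32)cc1`) gives 76.3 nM. Compound 3 thus stands level with compound 2 and clear of compound 1, as the data show a 1.1-fold lower number from compound 2 to compound 3 (0.05 log units; within the scatter) and a 3.9-fold lower number from compound 1 to compound 3 (0.60 log units; beyond the scatter).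

Compound 4 (`COc1ccc(S(=O)(=O)N2CCc3cccc(-c4ccc(C#N)cc4)c32)cc1`) has 4-cyanophenyl in place of pyridin-3-yl on an aromatic carbon. Among the compounds with values here, the nitrile itself has no measured precedent in this set, so the guidance is indirect. The nearest comparison is compound 2, which also bears a substituted phenyl at this place, and its exchange with pyridin-3-yl gave no real change. Only the 4-aminophenyl of compound 1 stands apart, with a 3.5-fold lower number from compound 1 to compound 2 (0.55 log units; beyond the scatter). No step beyond the scatter is therefore expected in this assay. The estimate amounts to a 1.3-fold higher number from compound 3 to compound 4 (0.12 log units; within the scatter). Compound 4 is expected at about 100 nM, within an estimated range of 35 nM to 280 nM.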

Compound 4, half-maximal inhibitory concentration: 24.2 nM
Compound 4: the middle estimate sits 4.1-fold (0.62 log units) above what was measured; measured number outside the range, below it.
By their numbers in this assay, from the lowest: compound 4; then compounds 3 and 2 (each within the scatter of the next); then compound 1.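

In this assay, going by these compounds alone, 4-cyanophenyl is the first group at this aromatic carbon to stand clear of both pyridin-3-yl and 4-fluorophenyl, with a 3.2-fold lower number from compound 3 to compound 4 (0.50 log units; beyond the scatter) and a 3.5-fold lower number from compound 2 to compound 4 (0.55 log units; beyond the scatter), although those two groups had themselves stayed within the scatter of each other. With the phenyl ring kept, the substituent on it therefore matters in both directions, as cyano in place of amino gives a 12-fold lower number from compound 1 to compound 4 (1.09 log units; beyond the scatter), the widest step in the set and larger than the step from amino to fluoro. Nothing given here accounts for this order.

Going by these compounds, it remains open whether the lower number depends on the nitrile itself or on where it sits on the phenyl ring, which a 3-cyanophenyl group would test. On these data alone, whether a carboxylic acid or a trifluoromethyl group at the same place on the ring would behave like the nitrile also remains open.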